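Replacing 3,4-dimethoxyphenyl with 3-fluorophenyl in the series

The source may hold more compounds than are shown below. What is called first, only, known or untested is meant among the compounds shown, and "the series" means these compounds.

In a functional assay on HL-60 cells (Homo sapiens) for inhibition, read by MTT assay, with a stated time of 72 h (on this read-out lower numbers stand for stronger inhibition and higher numbers for weaker inhibition), only compound 1 (`CCc1nc(-c2ccccc2F)c(C(=O)N2CCN(c3cccc(Cl)c3)CC2)o1`) gives a number, at 139 nM on this read-out. Compound 2 (`CCc1nc(-c2ccc(C(C)(C)C)cc2)c(C(=O)N2CCN(c3cccc(OC)c3)CC2)o1`) stands at "not active" (no number reported) in this assay on the same read-out. Compound 3 (`COc1ccc(-c2nc(C)oc2C(=O)N2CCN(c3cccc(Cl)c3)CC2)cc1OC`) stands at "not active" (no number reported) in this assay and so has no single number, a position it shares only with compound 2.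

Compound 4 (`Cc1nc(-c2cccc(F)c2)c(C(=O)N2CCN(c3cccc(Cl)c3)CC2)o1`) is still unmeasured. The change 3-fluorophenyl in place of 3,4-dimethoxyphenyl on an aromatic carbon puts 3-fluorophenyl in place of 3,4-dimethoxyphenyl on an aromatic carbon of the five-membered aromatic ring with 1 nitrogen and 1 oxygen.

With no number for compound 3, the step cannot be sized. The expected direction in this assay is toward stronger inhibition, from no reported number to a measurable one, and the expected step goes beyond the scatter. The support is thin: compound 1, which also carries a fluorine on its phenyl group, gives 139 nM while compound 2 and compound 3, without one, give no number. This rests on three compounds only, and a second outcome without a number remains possible. Compound 4 is estimated at 400 nM with an expected range of 70 nM to 3000 nM on this read-out.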

Compound 4, half-maximal inhibitory concentration: 33.7 nM
Compound 4: middle estimate off by 12-fold (1.07 log units), on the high side; measured number outside the range, below it.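

Going by these compounds alone, compound 3 has no single number in this assay while compound 4 gives 33.7 nM, and no step between them can be read. No available evidence speaks to a cause for this result. The compounds shown leave open how far 3-fluorophenyl in place of 3,4-dimethoxyphenyl alone shifts inhibition on this read-out.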